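The source may report more compounds than this note shows. Statements on the series, on what has been measured and on what is new or still open speak of the compounds shown alone.

Values in a functional assay on A2780 cells (Homo sapiens) for antiproliferative activity, with a stated time of 72 h; on this read-out higher numbers stand for weaker inhibition and lower numbers for stronger inhibition:
- compound 1 `CCC(c1nn2cc(Cl)cc2c(=O)n1Cc1ccccc1)N(CCCN)C(=O)c1ccc(C)cc1`: 980 nM
- compound 2 `NCCCN(Cc1nn2ccc(Cl)c2c(=O)n1Cc1ccccc1)C(=O)c1ccc(Cl)cc1`: > 10000 nM
- compound 3 `Cc1ccc(C(=O)N(CCC(N)=O)C(c2nn3c(Cl)ccc3c(=O)n2Cc2ccccc2)C2CC2)cc1`: 330 nM

Compound 2 gives > 10000 nM, which is a limit of the assay and not a number. From the compounds shown here alone, it stands at the limit of > 10000 nM in this assay, at which 1 of the 3 values shown sits, so its true value is unknown.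

Compound 4 `CCC(c1nn2ccc(Cl)c2c(=O)n1Cc1ccccc1)N(CCCN)C(=O)c1ccc(Cl)cc1` is compound 2 with a single change: ethyl in place of hydrogen on a saturated chain carbon bound to an amide-type nitrogen and an aromatic carbon. In words, an ethyl replaces a hydrogen on a saturated chain carbon bound to an amide-type nitrogen and an aromatic carbon.

Within the data shown here, no measured pair isolates this change, so the evidence is indirect. Compound 1 also carries an ethyl on that carbon, and compound 1 gives 980 nM, though it differs from compound 4 elsewhere as well. Compound 3 also has a substituent on that carbon, and compound 3 gives 330 nM. In this assay, a large step towards stronger inhibition is therefore expected, estimated as an at least 12-fold lower number from compound 2 to compound 4 (1.09 log units; beyond the scatter). For compound 4 the expected value is 800 nM, with an estimated range of 150 nM to 5000 nM.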

Compound 4, half-maximal inhibitory concentration: 440 nM
For compound 4 the middle estimate is 1.8-fold (0.26 log units) above the measured one, and the stated range covers the measured number.
By their numbers in this assay, from the lowest: compounds 3 and 4 (each within the scatter of the next); then compound 1. At a limit, above all of these: compound 2.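

Among these compounds, compound 4 gives the first direct reading of this change, because only one place differs from compound 2. In this assay, ethyl in place of hydrogen on the saturated chain carbon gives an at least 22-fold lower number from compound 2 to compound 4 (1.35 log units; beyond the scatter), a large step beyond the scatter. Compound 2 is a limit of the assay and not a number, so this step has a known minimum but no known full size: the limit of > 10000 nM in this assay, at which 1 of the 4 values shown sits. Compounds 1 and 3 had only hinted at the value of a substituent on this carbon, since each also differs elsewhere.

From the compounds shown here alone, what remains open is how much carbon this position needs, as a methyl or a longer chain such as propyl could give a different result. Going by these compounds, it is also open whether an amine on this carbon would be tolerated.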